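This account rests on a few compounds, and the source may have more. Where it says the series, first, only, none or still open, it means among the compounds named here.

Measured compounds:
Compound 1, `Cc1cc2cc(NS(=O)(=O)c3cc(C(=O)NO)ccc3Cl)ccc2n(C)c1=O`, in a functional assay on THP-1 cells (Homo sapiens) for antiproliferative activity, tested at 100 uM (a higher number here means a stronger effect of the compound at the concentration tested, a lower number a weaker effect), compound 1 gives 21%.
Compound 2, `COc1ccc(C(=O)NO)cc1S(=O)(=O)Nc1ccc2c(c1)cc(C)c(=O)n2C`, compound 2 gives 43%.
Compound 3, `COc1ccc(C(=O)NOCc2ccc(OC(C)=O)cc2)cc1S(=O)(=O)Nc1ccc2c(c1)cc(C)c(=O)n2C`, compound 3 gives 27%.

Compound 2 stands highest of the three in this assay. Its nearest neighbour is compound 3, and the step of a number 16 percentage points lower from compound 2 to compound 3 (beyond the scatter) lies beyond the scatter; the step of a number 22 percentage points higher from compound 1 to compound 2 (beyond the scatter) is also beyond the scatter.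

The unmeasured compound 4, `COC(=O)c1ccc(OC)c(S(=O)(=O)Nc2ccc3c(c2)cc(C)c(=O)n3C)c1`, differs from compound 2 by methoxy in place of hydroxyamino on a carbonyl carbon. Among the measured compounds shown here, no measured step makes this same change. The closest is the step from compound 2 to compound 3, where the oxygen of the hydroxyamino group was capped with 4-acetoxybenzyl and the number fell by a modest amount; changing the same group into methoxy is a change of comparable kind, so a modest decrease in this assay is expected, though the size is uncertain. Compound 4 is therefore expected to give 20%, within 5% to 40%, a step of a number 23 percentage points lower from compound 2 to compound 4 (beyond the scatter).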

Compound 4, a percentage reported as inhibition, at one concentration (the size of the read-out at that concentration, not a potency): 102%
Compound 4: middle estimate off by 82 percentage points, on the low side; measured number above the stated range.
By their numbers in this assay, from the lowest: compounds 1 and 3 (each within the scatter of the next); then compound 2; then compound 4.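

Among the compounds shown here, the carbonyl carbon that carries hydroxyamino proved far more sensitive in this assay than the earlier compounds suggested: the only earlier change at this group, capping its oxygen with 4-acetoxybenzyl, gave a number 16 percentage points lower from compound 2 to compound 3 (beyond the scatter), whereas replacing hydroxyamino with methoxy gave a number 59 percentage points higher from compound 2 to compound 4 (beyond the scatter). The two changes therefore move the number in opposite directions, so the hydroxycarbamoyl group is not needed for a high read-out in this series, and the step is larger than the one seen for chloro and methoxy on the aromatic carbon. Nothing in the information available accounts for this reversal.

On these data alone, it remains open whether a carboxylic acid, an ethyl ester or a primary amide on the same carbonyl carbon would behave like methoxycarbonyl. As far as these compounds go, it is also open whether methoxycarbonyl would give a similar result with chloro in place of the methoxy on the aromatic carbon.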